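Amino analogue of the acetamido compound: expected potency

A few compounds are considered here, and "the series" means these few. Any claim that something is new, unique, unknown or untested is made for them only; others in the source may bear on it.

Three measured compounds share one core and differ only in the group on the nitrogen on the aromatic ring. Compound 1 `CC(C)S(=O)(=O)Nc1cccc2c1CCCC2c1c[nH]cn1` carries an isopropylsulfonyl group; in a functional assay on Urethra for agonist activity at Alpha-1A adrenergic receptor (Oryctolagus cuniculus) (on this read-out higher numbers stand for higher potency (the scale is a negative logarithm) and lower numbers for lower potency), compound 1 gives 5.17. Compound 2 `O=S(=O)(Nc1cccc2c1CCCC2c1c[nH]cn1)C1CC1` carries a cyclopropylsulfonyl group, and in this assay compound 2 gives 5.25. That exchange amounts to a number 0.08 log units higher from compound 1 to compound 2 (within the scatter). Compound 3 `CC(=O)Nc1cccc2c1CCCC2c1c[nH]cn1` carries an acetyl group, and in this assay compound 3 gives 5.89, the highest of the three numbers. Both a number 0.72 log units higher from compound 1 to compound 3 (beyond the scatter) and a number 0.64 log units higher from compound 2 to compound 3 (beyond the scatter) lie beyond the scatter.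

Compound 4 `Nc1cccc2c1CCCC2c1c[nH]cn1` has not been measured. The change is hydrogen in place of acetyl on a nitrogen on an aromatic ring, which read one bond further out is acetamido to amino. Going by the values given here, no measured step removes the group on this nitrogen altogether; the two steps that bear on it only exchange one group for another, and both were modest gains on moving to acetyl. Among the compounds with values here, with no direct precedent, compound 4 is expected to give about 6 in this assay, within 5.3 to 6.8. The implied step a number 0.11 log units higher from compound 3 to compound 4 (within the scatter) is estimated to stay within the scatter.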

Compound 4, negative logarithm of the half-maximal effective concentration: 6.56
The estimate for compound 4 lay 0.56 log units below the measured number; low and high end bracket the measured number.
By their numbers in this assay, from the lowest: compounds 1 and 2 (each within the scatter of the next); then compound 3; then compound 4.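

In this assay, leaving the nitrogen on the aromatic ring without any group gives the highest number in the set, above acetyl (a number 0.67 log units higher from compound 3 to compound 4 (beyond the scatter)) and further above the two sulfonyl groups (a number 1.31 log units higher from compound 2 to compound 4 (beyond the scatter); a number 1.39 log units higher from compound 1 to compound 4 (beyond the scatter)). Acetyl, the best of the groups seen earlier on this nitrogen, therefore still falls short of plain hydrogen, and all three groups shown on this nitrogen stand below the free amino compound, with the sulfonyl groups lowest. Nothing measured here accounts for this order.

On these data alone, it remains open whether any group on this nitrogen is tolerated as well as hydrogen, for instance a single methyl or two methyls. As far as these compounds go, it is also open whether a hydroxyl in place of the amino group would hold the number reached by compound 4.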